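Aryl urea series: kinetic solubility, pyrazine to pyridine

The compounds below may be only part of what the source reports. "The series", "measured", "known", "first", "only" and "open" are said of these compounds alone.

Measured so far in a physicochemical assay for solubility, read by nephelometry, measured as kinetic solubility, at pH 2; a higher number here means a more soluble compound, a lower number a less soluble compound:
compound 1 `N#Cc1ccc(NC(=O)Nc2ccc(F)c(C(F)(F)F)c2)cc1`, reported only as a limit of the assay: < 1.6 ug/mL
compound 2 `O=C(Nc1ccc(F)c(C(F)(F)F)c1)Nc1cnccn1`: 1.6 ug/mL
compound 3 `CC(=O)c1ccc(NC(=O)Nc2ccc(F)c(C(F)(F)F)c2)cc1`, reported only as a limit of the assay: < 1.6 ug/mL

Among the measured compounds shown here, compound 2 stands as the only compound of the three with a number in this assay; the other two values sit at the limit of < 1.6 ug/mL in this assay, at which 2 of the 3 values shown sit. For the measured compounds named here, the single step between measured compounds, a step that the two limits leave unreadable from compound 1 to compound 3, runs between two limits and so gives no readable size.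

Compound 4 `O=C(Nc1cccnc1)Nc1ccc(F)c(C(F)(F)F)c1` is not yet measured. It differs from compound 2 as follows: pyridin-3-yl in place of pyrazin-2-yl on an amide-type nitrogen. Going by the values given here, no measured step touches the group on this amide-type nitrogen, so nothing in the numbers so far bears directly on this change, and the one step available is unreadable.

For compound 4 the expectation in this assay is therefore a value close to that of compound 2, with a real chance that the assay again returns only a limit; the expected step is no change at the digits printed from compound 2 to compound 4 (within the scatter). The estimate for compound 4 is 1.6 ug/mL, with a range from 0.8 ug/mL to 4 ug/mL.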

Compound 4, solubility: 50 ug/mL
Estimate against measurement, compound 4: 31-fold (1.49 log units) below; the whole stated range lies below it.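

In this assay, among the compounds shown here, pyridin-3-yl in place of pyrazin-2-yl on the amide-type nitrogen gives a 31-fold higher number from compound 2 to compound 4 (1.49 log units; beyond the scatter) and is the first readable step, so this position can move the reading strongly. The two groups have the same count of 6 heavy atoms and differ only in 5 carbon, 1 nitrogen against 4 carbon, 2 nitrogen, so a small change in ring atoms at this place is enough for a step of this size. The lower end of the step rests on a value with the same figure as the assay's limit: the limit of < 1.6 ug/mL in this assay, at which 2 of the 4 values shown sit.

The compounds shown do not separate the number of ring nitrogens from their placement as the source of the step. Also open, from the compounds shown here alone, is how this assay would read with an amine or a carboxylic acid carried on the pyridin-3-yl group.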